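The source may report more compounds than this note shows. Statements on the series, on what has been measured and on what is new or still open speak of the compounds shown alone.

Three compounds of the series have so far been run in a functional assay on HepG2 cells (Homo sapiens) for inhibition, read by MTT assay, with a stated time of 48 h; on this read-out higher numbers stand for weaker inhibition and lower numbers for stronger inhibition. Compound 1 `O=C(C=CNc1cc(-c2ccccc2)nn1-c1ccccc1)c1ccc(Br)cc1` gives 8810 nM. Compound 3 `O=C(C=CNc1cc(-c2ccccc2)nn1-c1ccccc1)c1ccc(F)cc1` shares the core of compound 1; in this assay compound 3 gives 59900 nM. Compound 2 `Fc1ccc(-c2ccnc3c2c(-c2ccccc2)nn3-c2ccccc2)cc1`, built on a different core, gives 1570 nM in this assay, the lowest of the three numbers, with compound 1 nearest and compound 3 furthest from it. How the core of compound 2 differs from the core of compound 3 is not broken down here.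

For the measured compounds named here, the only change measured within one core is bromo in place of fluoro on an aromatic carbon, and this step reads a 6.8-fold lower number from compound 3 to compound 1 (0.83 log units; beyond the scatter).

Compound 4 `Brc1ccc(-c2ccnc3c2c(-c2ccccc2)nn3-c2ccccc2)cc1` has not yet been run in this assay. It differs from compound 2 by bromo in place of fluoro on an aromatic carbon. The place of this change is the same, word for word, as for compound 3 to compound 1, so it is the same change, seen once before among these compounds; cut one bond further out it reads 4-fluorophenyl to 4-bromophenyl in both pairs. Any expectation for compound 4 therefore rests on a single earlier step, made on a different core, and no second example on the core of compound 2 exists. Set beside a 6.8-fold lower number from compound 3 to compound 1 (0.83 log units; beyond the scatter), the step is expected to be a 3.5-fold lower number from compound 2 to compound 4 (0.54 log units; beyond the scatter) in this assay, somewhat smaller than the earlier one. In this assay compound 4 is estimated at 450 nM, with a range from 150 nM to 1500 nM.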

Compound 4, half-maximal inhibitory concentration: 49900 nM
The estimate for compound 4 lay 110-fold (2.04 log units) below the measured number; the whole stated range lies below it.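

In this assay, the change from 4-fluorophenyl to 4-bromophenyl reads a 32-fold higher number from compound 2 to compound 4 (1.50 log units; beyond the scatter), a large step on the core of compound 2. Set beside the earlier step on the core of compound 1, the same change does not carry from one core to the other in either size or direction, so within these compounds the result of this swap cannot be read across cores: the same change on two cores in this assay, a 6.8-fold lower number (0.83 log units; beyond the scatter) from compound 3 to compound 1 and a 32-fold higher number (1.50 log units; beyond the scatter) from compound 2 to compound 4, 220-fold (2.33 log units) apart, beyond the scatter of two such steps

This rests on one pair per core, so it shows that the core can reverse the outcome of this change but does not show why, nor how either step would hold up with further pairs on the same core or on a third core.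

Open, as far as these compounds go, is whether chloro or iodo at the same place would follow the step seen on the core of compound 2 or the one seen on the core of compound 1, which would show whether bromo stands alone on either core. Also open, from the compounds shown here alone, is how a group of a different kind there, such as an amine, a carboxylic acid or a longer chain, would read on each of the two cores.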